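This account rests on a few compounds, and the source may have more. Where it says the series, first, only, none or still open, it means among the compounds named here.

In an assay on HEK293 cells for antagonist activity at P2X purinoceptor 7 (Homo sapiens), read by fluorescence, with a stated time of 2 h (on this read-out lower numbers stand for stronger inhibition and higher numbers for weaker inhibition), compound 3 `O=C(c1ccc(Cl)c(C(F)(F)F)c1)N1CCC(n2cncc2-c2ccc(OS(=O)(=O)c3cccc(Br)c3)cc2)CC1` gives 896 nM, the lowest of the two numbers shown. The nearest is compound 1 `CS(=O)(=O)Oc1ccc(-c2cncn2C2CCN(C(=O)c3ccc(Cl)c(C(F)(F)F)c3)CC2)cc1`, which gives 1570 nM; the step of a 1.8-fold lower number from compound 1 to compound 3 (0.24 log units; within the scatter) lies within the scatter, so no order between the two can be claimed. Compound 2 `O=C(Oc1ccc(-c2cncn2C2CCN(C(=O)c3ccc(Cl)c(C(F)(F)F)c3)CC2)cc1)c1cccs1` is reported only as a limit, > 10000 nM, which is the limit of > 10000 nM in this assay, at which 1 of the 3 values shown sits. The steps of an at least 6.3-fold higher number from compound 1 to compound 2 (0.80 log units; beyond the scatter) and an at least 11-fold lower number from compound 2 to compound 3 (1.04 log units; beyond the scatter) both exchange the whole group on the aromatic oxygen and say nothing about a substituent on the 3-bromophenyl. Compound 4 `CNC(=O)c1cccc(S(=O)(=O)Oc2ccc(-c3cncn3C3CCN(C(=O)c4ccc(Cl)c(C(F)(F)F)c4)CC3)cc2)c1` differs from compound 3 by methylcarbamoyl in place of bromo on an aromatic carbon. Among the measured compounds shown here, no measured step touches that part of the molecule, and the closest comparison, the step from compound 1 to compound 3, stayed within the scatter when the 3-bromophenyl replaced methyl. The step in this assay is therefore expected to be small, a 1.3-fold higher number from compound 3 to compound 4 (0.13 log units; within the scatter), with no direction beyond the scatter claimed. Compound 4 is expected to give about 1200 nM, with a range from 400 nM to 4000 nM.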

Compound 4, half-maximal inhibitory concentration: 112 nM
Compound 4: middle estimate off by 11-fold (1.03 log units), on the high side; the measured number lies below the stated range.
By their numbers in this assay, from the lowest: compound 4; then compounds 3 and 1 (each within the scatter of the next). At a limit, above all of these: compound 2.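

Earlier, replacing methyl on the sulfonyl sulfur with 3-bromophenyl had stayed within the scatter, which gave no sign that this part of the molecule mattered. In this assay, the substituent on that phenyl ring does matter, with an 8.0-fold lower number from compound 3 to compound 4 (0.90 log units; beyond the scatter) when methylcarbamoyl replaces bromo. The whole group exchange gives a 14-fold lower number from compound 1 to compound 4 (1.15 log units; beyond the scatter) and so is also beyond the scatter, but nothing measured here gives a reason for either step.

The compounds shown leave open whether the amide hydrogen of methylcarbamoyl is needed, which a dimethylcarbamoyl group would test, and whether a carboxylic acid or an amine on that aromatic carbon would give a similar number. They also leave open how methylcarbamoyl would fare on another carbon of that ring.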